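A Fluoro for Chloro Swap in a Narrow Series

The source may hold more compounds than are shown below. What is called first, only, known or untested is meant among the compounds shown, and "the series" means these compounds.

In a functional assay on cells (Tumor Cell line, Homo sapiens) for inhibition (a higher number here means a weaker inhibitor of growth, a lower number a stronger inhibitor of growth), compound 1 (`Cc1ccnc2nc(-c3cccc(Cl)c3)cc(O)c12`) gives 25700 nM and compound 2 (`Cc1ccc2c(O)cc(-c3cccc(Cl)c3)nc2n1`) gives 21400 nM while compound 3 (`Cc1cnc2[nH]c(-c3cccc(Cl)c3)cc(=O)c2c1`) gives 30900 nM and so lies within the scatter of both others. Compound 4 (`Cc1cnc2[nH]c(-c3cccc(F)c3)cc(=O)c2c1`) has fluoro in place of chloro on an aromatic carbon compared with compound 3. Going by the values given here, no step between measured compounds shows what such an exchange does, and the three close values offer the only guide. In this assay the estimated step of a 1.0-fold higher number from compound 3 to compound 4 (0.02 log units; within the scatter) is expected to stay within the scatter, with no firm direction. The expected value for compound 4 is 32000 nM with an estimated range from 17000 nM to 60000 nM around it.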

Compound 4, concentration for total growth inhibition: 5130 nM
For compound 4 the middle estimate is 6.2-fold (0.80 log units) above the measured one, outside the stated range (below it).
By their numbers in this assay, from the lowest: compound 4; then compounds 2, 1 and 3 (each within the scatter of the next).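

In this assay fluoro in place of chloro on the aromatic carbon gives a 6.0-fold lower number from compound 3 to compound 4 (0.78 log units; beyond the scatter) and this is the only listed step, one that lies beyond the scatter. It shows that this place on the ring, meta to a large group, responds to the exchange of one halogen for the other, which the three close earlier values could not reveal. Nothing measured here accounts for the size of this step. Going by these compounds, whether the same exchange acts alike on the cores of compound 1 and compound 2 stays open. So does the outcome with a hydrogen, a methoxy group or a nitrile at this place.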